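The source may report more compounds than this note shows. Statements on the series, on what has been measured and on what is new or still open speak of the compounds shown alone.

In an ADME assay on L6 cells (Rattus norvegicus) for cytotoxicity, read by resazurin assay, with a stated time of 70 h (a lower number here means a stronger inhibitor, a higher number a weaker inhibitor), three compounds have been measured so far. Compound 1 `CC(C)NC(=N)c1ccc2oc(-c3cccc(OCCCOc4ccccc4)c3)cc2c1` gives 26500 nM, compound 2 `N=C(N)c1ccc2oc(-c3cccc(OCCCCCOc4ccccc4)c3)cc2c1` gives 3000 nM, and compound 3 `N=C(N)c1ccc2cc(-c3cccc(OCCCOc4ccccc4)c3)oc2c1` gives 19800 nM. Compound 3 stands second highest of the three numbers; its nearest neighbour is compound 1, whose number lies within the scatter of it, and its furthest is compound 2, whose lower number lies beyond the scatter. Compound 4 `c1ccc(OCCCOc2cccc(-c3cc4ccc(C5=NCCN5)cc4o3)c2)cc1` differs from compound 3 in one place: a group of 5 heavy atoms (3 carbon, 2 nitrogen; one five-membered non-aromatic ring with 2 hetero atoms) in place of a group of 3 heavy atoms (1 carbon, 2 nitrogen; no ring), on an aromatic carbon. Among the measured compounds shown here, no measured pair shows this change, so its size is not known from the data. The expected step from compound 3 to compound 4 in this assay is a 1.0-fold higher number from compound 3 to compound 4 (0.00 log units; within the scatter), taken to lie within the scatter. For compound 4 the estimate is 20000 nM, with a range from 7000 nM to 60000 nM.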

Compound 4, half-maximal inhibitory concentration: 10100 nM
Estimate against measurement, compound 4: 2.0-fold (0.30 log units) above; low and high end bracket the measured number.
By their numbers in this assay, from the lowest: compound 2; then compounds 4, 3 and 1 (each within the scatter of the next, the first and the last beyond it).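

In this assay, among the compounds shown here, the change reads a 2.0-fold lower number from compound 3 to compound 4 (0.29 log units; within the scatter) and so gives this exchange a size that the earlier compounds could not. On this aromatic carbon, the five-membered non-aromatic ring with 2 hetero atoms stands in place of the open group of 3 heavy atoms without leaving the scatter. No measured property bears on this step.

For the compounds shown here, the single pair leaves open whether the same exchange gives a similar step on the compound 2 scaffold, with its longer chain. It also leaves open how a six-membered ring, an amine or a carboxylic acid on this carbon would read.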